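The source may hold more compounds than are shown below. What is called first, only, known or untested is meant among the compounds shown, and "the series" means these compounds.

For the measured compounds named here, in an ADME assay on microsomes from liver (Homo sapiens) for metabolic stability, read by LC-MS, using NADPH, with stated times of 10 min and 30 min (on this read-out higher numbers stand for fast clearance and lower numbers for slow clearance), compound 1 `CCC1c2cc(Cl)ccc2C(=O)N1c1cccnc1` gives 6.6 mL/min/kg, the only actual number available so far. Compound 2 `CS(=O)(=O)N[C@@H]1CCCc2c1cncc2N1CCc2cc(Cl)ccc2C1=O` is reported in this assay as < 3.5 mL/min/kg, and this is a limit of the assay, not a number. Going by the values given here, no two measured compounds here differ in one place only, so the data hold no direct precedent for a single change.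

Compound 3 `O=C1c2ccc(Cl)cc2C(C2CC2)N1c1cccnc1` has not yet been measured. It keeps the core of compound 1 but carries cyclopropyl in place of ethyl on a saturated ring carbon, next to the ring nitrogen and next to the ring atom that bears a pyridin-3-yl group: cyclopropyl in place of ethyl on a saturated ring carbon. The expectation for it rests on compound 1 alone, at 6.6 mL/min/kg. The estimated step of a 1.1-fold lower number from compound 1 to compound 3 (0.04 log units; within the scatter) is expected to stay within the usual scatter of this assay, with no clear direction. Compound 3 is estimated at 6 mL/min/kg, with an expected range from 3.5 mL/min/kg to 12 mL/min/kg.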

Compound 3, clearance: 9.4 mL/min/kg
Compound 3: middle estimate off by 1.6-fold (0.19 log units), on the low side; measured number inside the range.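

In this assay, for the compounds shown here, the exchange of ethyl for cyclopropyl on a saturated ring carbon gives the first direct precedent at this position: a 1.4-fold higher number from compound 1 to compound 3 (0.15 log units; within the scatter). At this place, on the five-membered non-aromatic ring and next to the ring nitrogen, a larger group carrying a three-membered ring of carbon only leaves compound 1 and compound 3 within the scatter of each other, so on this read-out the two have to be treated as alike. Compound 2 adds nothing to this comparison, as it differs from both in more than one place and its entry is a limit of the assay, not a number: the limit of < 3.5 mL/min/kg in this assay, at which 1 of the 3 values shown sits.

The compounds shown leave open whether a group of another kind on this carbon, such as an amine, a methoxymethyl group or a longer chain like butyl, would take the clearance reading beyond the scatter. They also leave open whether the same exchange would read alike on any other core, and a single pair gives no rule for that.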